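The compounds below may be only part of what the source reports. "The series", "measured", "known", "first", "only" and "open" are said of these compounds alone.

In a functional assay on K562 cells (Homo sapiens) for cytotoxicity, read by trypan blue exclusion, with a stated time of 96 h (on this read-out higher numbers stand for weaker inhibition and lower numbers for stronger inhibition), compound 1 `COc1ccc(/C=C/S(=O)(=O)Cc2ccc(OC)c(N)c2)cc1` gives 2500 nM and compound 2 `COc1ccc(/C=C/S(=O)(=O)Cc2ccc(OC)c(N)c2)c(OC)c1` gives 500 nM, the lower of the two numbers. Compound 3 `COc1cc(OC)c(/C=C/S(=O)(=O)Cc2ccc(OC)c(N)c2)c(OC)c1` differs from compound 2 in one place: methoxy in place of hydrogen on an aromatic carbon, a methoxy in place of hydrogen on an aromatic carbon, ortho to a large group and meta to two methoxy groups. Among the measured compounds shown here, only one measured step shows this kind of swap: a 5.0-fold lower number from compound 1 to compound 2 (0.70 log units; beyond the scatter), modest but beyond the scatter. With that single guide, a similar or slightly larger drop is expected, an estimated 8.3-fold lower number from compound 2 to compound 3 (0.92 log units; beyond the scatter). In this assay, the expected value for compound 3 is 60 nM, with an estimated range of 10 nM to 300 nM.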

Compound 3, half-maximal inhibitory concentration: 2.5 nM
The estimate for compound 3 lay 24-fold (1.38 log units) above the measured number; the whole stated range lies above it.
By their numbers in this assay, from the lowest: compound 3; then compound 2; then compound 1.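

In this assay, a methoxy placed on this aromatic carbon, ortho to a large group and meta to two methoxy groups, gives a 200-fold lower number from compound 2 to compound 3 (2.30 log units; beyond the scatter), whereas the same kind of swap at the other position gave only a 5.0-fold lower number from compound 1 to compound 2 (0.70 log units; beyond the scatter). Across these three compounds, then, the size of the step depends strongly on where the methoxy lands on the ring. Nothing available here explains this difference.

From the compounds shown here alone, it remains open whether an ethoxy or an amine on this carbon would match the methoxy, and whether this methoxy would give a similar step without the two methoxy groups already on the ring.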